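From chloro to cyclopropylamino at the assay limit

A few compounds are considered here, and "the series" means these few. Any claim that something is new, unique, unknown or untested is made for them only; others in the source may bear on it.

Measured in an ADME assay on L1210/0 cells (Mus musculus) for cytotoxicity, with a stated time of 48 h; on this read-out lower numbers stand for stronger inhibition and higher numbers for weaker inhibition:
- compound 1 `Cc1ccc(-c2ncnc3c2ncn3C[C@@H]2C[C@H](CO)c3ccccc32)cc1` gives 15400 nM
- compound 2 `OC[C@@H]1C[C@H](Cn2cnc3c(Cl)ncnc32)c2c(-c3ccccc3)nnc(-c3ccccc3)c21` gives > 200000 nM (a limit, not a number)

For compound 2 the assay yields only a limit and no number (the limit of > 200000 nM in this assay, at which 1 of the 2 values shown sits). Compound 3 `OC[C@@H]1C[C@H](Cn2cnc3c(NC4CC4)ncnc32)c2c(-c3ccccc3)nnc(-c3ccccc3)c21` shares its core and carries cyclopropylamino in place of chloro on an aromatic carbon. Among the measured compounds shown here, no measured step shows what this exchange does in this assay, so only a modest move towards stronger inhibition is expected, and compound 3 may also return a limit. That expectation leans on compound 1 with 15400 nM, which shows that this assay can return a number for a compound with a different core. The expected change is an at least 2.0-fold lower number from compound 2 to compound 3 (0.30 log units; that floor lies within the scatter), an estimate set against a limit. For compound 3 the estimate is 100000 nM, expected to fall between 30000 nM and 200000 nM in repeat measurements.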

Compound 3, half-maximal inhibitory concentration: > 200000 nM
Compound 3 ended at the assay's limit; the forecaster's own chance of this, stated with the estimate: 50%; middle value at least 2.0-fold (0.30 log units) from the limit.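

In this assay compound 3 gives > 200000 nM, a limit and not a number. Compound 2 also stands at a limit, so no step can be read between compound 2 and compound 3. The compounds shown leave open what cyclopropylamino in place of chloro does to inhibition.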